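Swapping pyrrolidin-3-yl for 2-aminoethyl

This account rests on a few compounds, and the source may have more. Where it says the series, first, only, none or still open, it means among the compounds named here.

Measured in a functional assay on OCI-Ly10 cells (Homo sapiens) for cytotoxicity, read by CCK-8 assay, with a stated time of 72 h; a lower number here means a stronger inhibitor, a higher number a weaker inhibitor
Compound 1 `Cn1cc(NC(=O)c2cnc3ccc(N[C@H]4CCCNC4)nn23)c(C(F)F)n1` gives 22300 nM
Compound 2 `Cn1cc(NC(=O)c2cnc3ccc(N[C@@H]4CCNC4)nn23)c(C(F)F)n1` gives 3600 nM

Compound 2 at 3600 nM holds the lower of the two values. Compound 3 `Cn1cc(NC(=O)c2cnc3ccc(NCCN)nn23)c(C(F)F)n1` differs from it by one change (2-aminoethyl in place of pyrrolidin-3-yl on a nitrogen on an aromatic ring), with 2-aminoethyl in place of pyrrolidin-3-yl on the same nitrogen. Within the data shown here, one measured step bears on this, the modest 6.2-fold lower number from compound 1 to compound 2 (0.79 log units; beyond the scatter) on swapping piperidin-3-yl for pyrrolidin-3-yl. Among the measured compounds shown here, no measured compound lacks a ring there, so the direction is uncertain, but a modest rise in this assay is expected. The estimate for compound 3 is 8000 nM (range 2000 nM to 30000 nM). This estimate means a 2.2-fold higher number from compound 2 to compound 3 (0.35 log units; beyond the scatter) as the expected step.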

Compound 3, half-maximal inhibitory concentration: 8800 nM
The estimate for compound 3 lay 1.1-fold (0.04 log units) below the measured number; measured number inside the range.
By their numbers in this assay, from the lowest: compound 2; then compound 3; then compound 1.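

In this assay, an open chain on this nitrogen gives a value within the range set by the two ring amines: replacing the ring gives a 2.4-fold higher number from compound 2 to compound 3 (0.39 log units; beyond the scatter) and also a 2.5-fold lower number from compound 1 to compound 3 (0.40 log units; beyond the scatter). A ring at this position is therefore not required to reach these values, although compound 2, with pyrrolidin-3-yl, keeps the lowest number of the three. Nothing available explains this order.

Still open, as far as these compounds go, is how a longer chain such as 3-aminopropyl would compare with 2-aminoethyl. Also open, from the compounds shown here alone, is whether the terminal amine matters, which 2-hydroxyethyl would test.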